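From 2-chlorophenyl to 3-chlorophenyl: a small change

A few compounds are considered here, and "the series" means these few. Any claim that something is new, unique, unknown or untested is made for them only; others in the source may bear on it.

Measured in a functional assay on OVCAR-3 cells (Homo sapiens) for antiproliferative activity, read by MTT assay, with a stated time of 24 h; a higher number here means a weaker inhibitor, a lower number a stronger inhibitor:
- Compound 1 `O=C(NNc1cccc(Cl)c1)c1cccc(NS(=O)(=O)c2cnc(O)nc2O)c1`: 8040 nM
- Compound 2 `Cc1ccc(C(=O)NNC(=O)c2cccc(NS(=O)(=O)c3cnc(O)nc3O)c2)cc1`: > 20000 nM, a limit of the assay
- Compound 3 `O=C(NNC(=O)c1ccccc1Cl)c1cccc(NS(=O)(=O)c2cnc(O)nc2O)c1`: 7300 nM

Only two of these results are true numbers, and compound 3 stands level with compound 1. That step is small, a 1.1-fold lower number from compound 1 to compound 3 (0.04 log units; within the scatter). The remaining step is larger and reaches past the scatter, an at least 2.7-fold lower number from compound 2 to compound 3 (0.43 log units; beyond the scatter).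

Compound 4 `O=C(NNC(=O)c1cccc(NS(=O)(=O)c2cnc(O)nc2O)c1)c1cccc(Cl)c1` has the same atoms as compound 3, joined differently: 3-chlorophenyl in place of 2-chlorophenyl on a carbonyl carbon. It carries 3-chlorophenyl in place of 2-chlorophenyl on a carbonyl carbon. Going by the values given here, no measured step makes exactly this change. The small step to compound 3 suggests that the two chlorophenyl groups may be interchangeable, a 1.1-fold lower number from compound 1 to compound 3 (0.04 log units; within the scatter). The step away from 4-methylphenyl warns that the group on this carbonyl carbon can matter, an at least 2.7-fold lower number from compound 2 to compound 3 (0.43 log units; beyond the scatter). In this assay, no change beyond the scatter is therefore expected.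

The estimated step is a 1.2-fold higher number from compound 3 to compound 4 (0.07 log units; within the scatter).

For compound 4, the expected value is 8500 nM, with an estimated range of 3500 nM to 20000 nM.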

Compound 4, half-maximal inhibitory concentration: 13500 nM
Beside the measured number, compound 4's estimate is 1.6-fold (0.20 log units) below it; the range from low to high includes it.
By their numbers in this assay, from the lowest: compounds 3, 1 and 4 (each within the scatter of the next). At a limit, above all of these: compound 2.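

Placing 3-chlorophenyl in place of 2-chlorophenyl on the carbonyl carbon gives a step that stays within the scatter in this assay (a 1.8-fold higher number from compound 3 to compound 4 (0.27 log units; within the scatter)), so this change does not separate the two chlorophenyl groups at this position. The change from 3-chlorophenyl on an amine nitrogen to (3-chlorophenyl)carbonyl also stays within the scatter (a 1.7-fold higher number from compound 1 to compound 4 (0.23 log units; within the scatter)), so the added carbonyl has no readable effect here. Compound 2 carries a limit and not a number, so its step gives only a floor (an at least 1.4-fold lower number from compound 2 to compound 4 (0.17 log units; that floor lies within the scatter)), and 3-chlorophenyl is not clearly set apart from 4-methylphenyl: the limit of > 20000 nM in this assay, at which 1 of the 4 values shown sits.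

From the compounds shown here alone, it remains open whether the position tolerates anything other than these aromatic groups, such as a carboxylic acid or an amine in place of the chlorine. A longer chain between the carbonyl and the ring is equally untested by the compounds shown.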